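The source may hold more compounds than are shown below. What is called first, only, known or untested is meant among the compounds shown, and "the series" means these compounds.

Compound 1, `O=S(=O)(Nc1ccc2oc(-c3ccccc3)nc2c1)c1ccccc1O`, is one of three measured members of a small series. In an assay on isolated protein for inhibition of malate dehydrogenase, mitochondrial (Sus scrofa), with stated times of 45 min and 30 min (on this read-out lower numbers stand for stronger inhibition and higher numbers for weaker inhibition), compound 1 gives > 63000 nM, which is a limit of the assay rather than a number. Compound 2, `O=S(=O)(Nc1ccc(-c2nc3ccccc3o2)cc1)c1cccc(O)c1`, is a positional relative; in this assay compound 2 gives > 63000 nM, again a limit. Compound 3, `O=S(=O)(Nc1ccc(-c2nc3ccccc3o2)cc1)c1ccccc1Cl`, also reaches only a limit, giving > 63000 nM in this assay. Going by the values given here, the one step between measured compounds, a step that the two limits leave unreadable from compound 2 to compound 3, is therefore unreadable, and the only evidence across the set is the limit of > 63000 nM in this assay, at which 3 of the 3 values shown sit. Compound 4, `O=S(=O)(Nc1ccc2oc(-c3ccccc3)nc2c1)c1ccc(Cl)cc1`, has not yet been measured. It differs from compound 1 in one place: 4-chlorophenyl in place of 2-hydroxyphenyl on a sulfonyl sulfur. Among the compounds with values here, no measured step shows what such a change on the sulfonyl sulfur does here, so no direction beyond the scatter can be expected. Compound 4 is estimated to give 80000 nM in this assay, between 25000 nM and 250000 nM, most probably again a limit, which means an expected step that the limit leaves unreadable from compound 1 to compound 4.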

Compound 4, half-maximal inhibitory concentration: > 63000 nM
Compound 4 was reported as a limit (the forecaster's own chance of this, stated with the estimate: 85%); the middle value does not contradict the limit.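

Compound 1 and compound 4 both reach only a limit in this assay, so no step can be read between them. What any group on the sulfonyl sulfur does to inhibition remains open, since the compounds shown offer only this: the limit of > 63000 nM in this assay, at which 4 of the 4 values shown sit.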